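The compounds below may be only part of what the source reports. "The series", "measured", "known", "first", "only" and "open" are said of these compounds alone.

Three compounds share a single core and were measured in an assay on isolated protein for inhibition of MAP kinase-activated protein kinase 2 (Homo sapiens), read by mobility shift assay, tested at 30 uM; a lower number here means less inhibition, a higher number more inhibition at the concentration tested (going by the name of the read-out). Compound 1 `Nc1n[nH]c2cc(-c3ccccn3)[nH]c(=O)c12` gives 41%. Compound 2 `COc1ccc(-c2cc3[nH]nc(N)c3c(=O)[nH]2)cc1` gives 59%, and compound 3 `CN1CCN(c2ccc(-c3cc4[nH]nc(N)c4c(=O)[nH]3)cc2)CC1` gives 55%. On these numbers compound 2 has the highest value of the three; its gap to compound 3 is within the scatter, while its gap to compound 1 lies beyond it. Within the data shown here, the one step between neighbours, a number 4 percentage points lower from compound 2 to compound 3 (within the scatter), swaps one group on the aromatic ring for another and leaves the read-out essentially unchanged.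

Compound 4 `COc1ccc(-c2cc3c(c(N)nn3C)c(=O)[nH]2)cc1` has not been measured. It differs from compound 2 in one place, (methyl in place of hydrogen on an aromatic nitrogen). Among the measured compounds shown here, no measured step touches this position: the only step available concerns the pendant aromatic ring, not the aromatic nitrogen of the fused five-membered ring, so none of the measured steps bears directly on the change. Without such a precedent the expectation rests on compound 2 alone, with a wide margin because the unexplored position leaves the direction of any shift open. Compound 4 is therefore expected to give about 40%, with a range from 5% to 65%. This estimate corresponds to an expected step of a number 19 percentage points lower from compound 2 to compound 4 (beyond the scatter).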

Compound 4, a percentage reported as inhibition, at one concentration (the size of the read-out at that concentration, not a potency): 51%
Compound 4: middle estimate off by 11 percentage points, on the low side; low and high end bracket the measured number.
By their numbers in this assay, from the lowest: compounds 1, 4, 3 and 2 (each within the scatter of the next, the first and the last beyond it).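

In this assay, among these compounds, methyl in place of hydrogen on an aromatic nitrogen of the five-membered aromatic ring gives a number 8 percentage points lower from compound 2 to compound 4 (within the scatter), and this is the first reading at this position, since the only earlier step concerned a group on the pendant aromatic ring. The read-out therefore does not depend measurably on that hydrogen in this one pair, at the single concentration tested, although a single pair within the scatter cannot show that the two compounds are equal or establish a rule for the series. Nothing available here accounts for this result or relates it to any property of the methyl group.

What the compounds shown leave open is whether the nitrogen would accept more than a methyl, for instance an ethyl group, a longer chain ending in an amine, or a chain ending in a carboxylic acid. They also leave open whether the same methyl would give a similar reading alongside the 4-methylpiperazin-1-yl group of compound 3 or the pendant ring of compound 1, and how any of these compounds would compare as a potency rather than at one concentration.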